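From Methyl Ester to Ethyl Ester: Compound 4

This account rests on a few compounds, and the source may have more. Where it says the series, first, only, none or still open, it means among the compounds named here.

Measured compounds:
- compound 1, `NS(=O)(=O)NCC1CCN(c2cc(-c3ccccc3)ncn2)CC1`: in a functional assay on M21 cells (Homo sapiens) for antiproliferative activity, read by sulforhodamine B assay, with a stated time of 48 h (on this read-out lower numbers stand for stronger inhibition of growth and higher numbers for weaker inhibition of growth), compound 1 reaches only the assay limit, > 100000 nM.
- compound 2, `NS(=O)(=O)NCC1CCN(c2cc(-c3ccc(Cl)cc3)ncn2)CC1`: compound 2 gives 50300 nM.
- compound 3, `COC(=O)c1ccc(-c2cc(N3CCC(CNS(N)(=O)=O)CC3)ncn2)cc1`: compound 3 gives 14100 nM.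

The value for compound 1 is a limit of the assay, not a number. Among the two actual numbers, compound 3 stands lowest, with compound 2 nearest at a 3.6-fold lower number from compound 2 to compound 3 (0.55 log units; beyond the scatter). Against the limit of compound 1, the step to compound 3 reads an at least 7.0-fold lower number from compound 1 to compound 3 (0.85 log units; beyond the scatter), whereas an at least 1.9-fold lower number from compound 1 to compound 2 (0.29 log units; that floor lies within the scatter) sits at its floor.

Compound 4, `CCOC(=O)c1ccc(-c2cc(N3CCC(CNS(N)(=O)=O)CC3)ncn2)cc1`, differs from compound 3 by methyl in place of hydrogen on a saturated chain carbon bound to an oxygen next to a carbonyl group. Within the data shown here, all three measured steps concern the substituent on the aromatic carbon; none touches the alkyl part of the ester, so no step gives direct guidance on this change. With nothing pointing either way, compound 4 is expected to stay close to compound 3, a step of a 1.2-fold lower number from compound 3 to compound 4 (0.07 log units; within the scatter) that is not expected to exceed the scatter. The estimate for compound 4 is therefore 12000 nM, within a range from 4500 nM to 35000 nM.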

Compound 4, concentration for 50% growth inhibition: 5000 nM
Compound 4: the middle estimate sits 2.4-fold (0.38 log units) above what was measured; low and high end bracket the measured number.
By their numbers in this assay, from the lowest: compound 4; then compound 3; then compound 2. At a limit, above all of these: compound 1.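

Among these compounds, the alkyl part of the ester turns out to matter, which the earlier steps could not show, since they changed only the substituent on the aromatic carbon: in this assay, a single methyl added on the saturated chain carbon bound to the oxygen gives a 2.8-fold lower number from compound 3 to compound 4 (0.45 log units; beyond the scatter). Measured against chloro, ethoxycarbonyl gives a 10-fold lower number from compound 2 to compound 4 (1.00 log units; beyond the scatter), so this ester now stands clearly apart from the chloro compound. Compound 1 sits at a limit of the assay, not a number, so an at least 20-fold lower number from compound 1 to compound 4 (1.30 log units; beyond the scatter) is only a floor: the limit of > 100000 nM in this assay, at which 1 of the 4 values shown sits.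

The compounds shown leave open whether a longer chain, such as a propyl ester, would lower the number further. They also leave open whether a carboxylic acid or an amide could take the place of the ester.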